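Trimming the amide substituent: cyclopentyl to isopropyl

The source may hold more compounds than are shown below. What is called first, only, known or untested is meant among the compounds shown, and "the series" means these compounds.

For the measured compounds named here, compound 2 `CCCn1cc(Cc2ccc(C(=O)NS(=O)(=O)c3ccccc3C)cc2OC)c2cc(C(=O)NCC3CCCC3)ccc21` gives 8.7 in an assay on isolated protein for binding affinity to cysteinyl leukotriene receptor 1 (Cavia porcellus) (a lower number here means a less potent compound, a higher number a more potent compound, by a factor of ten per unit of this negative logarithm), one of two numbers so far and within the scatter of compound 1 `CCCn1cc(Cc2ccc(C(=O)NS(=O)(=O)c3ccccc3C)cc2OC)c2cc(C(=O)NCC(CC)CC)ccc21`, which gives 8.9. Going by the values given here, the only step bearing on the change is a number 0.20 log units lower from compound 1 to compound 2 (within the scatter), which swapped pentan-3-yl for cyclopentyl. Compound 3 `CCCn1cc(Cc2ccc(C(=O)NS(=O)(=O)c3ccccc3C)cc2OC)c2cc(C(=O)NCC(C)C)ccc21` carries isopropyl in place of cyclopentyl on a saturated chain carbon bound to an amide-type nitrogen. Since that single step was small, no movement beyond the scatter is expected in this assay, though a slight loss is thought more likely than a gain. Compound 3 is estimated at 8.5, with a range of 7.9 to 9.1. The expected step is a number 0.20 log units lower from compound 2 to compound 3 (within the scatter).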

Compound 3, negative logarithm of the antagonist equilibrium constant: 9.1
The estimate for compound 3 lay 0.60 log units below the measured number; the measured number falls inside the stated range.
By their numbers in this assay, from the lowest: compounds 2, 1 and 3 (each within the scatter of the next, the first and the last beyond it).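

In this assay, for the compounds shown here, replacing the ring with open-chain isopropyl on this saturated chain carbon costs nothing: the change gives a number 0.40 log units higher from compound 2 to compound 3 (beyond the scatter), the first step at this position to leave the scatter. Between the two open-chain groups, the change from pentan-3-yl to isopropyl gives a number 0.20 log units higher from compound 1 to compound 3 (within the scatter), so compound 1 and compound 3 cannot be told apart, although isopropyl carries fewer heavy atoms. Nothing measured here accounts for these results. As far as these compounds go, it remains open how a methyl, a cyclohexyl or a phenyl group would fare here, and whether an amine or a carboxylic acid on this chain would be tolerated.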